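The compounds below may be only part of what the source reports. "The series", "measured", "known", "first", "only" and "open" are said of these compounds alone.

Working notes on the series. Among the measured compounds shown here, in a functional assay on HepG2 cells (Homo sapiens) for antiproliferative activity, read by sulforhodamine B assay, with a stated time of 48 h (a lower number here means a stronger inhibitor, a higher number a weaker inhibitor), compound 1 (`COc1ccc(-c2ccccc2C(=O)/C=C/c2ccc(F)cc2)cc1OC`) gives 4300 nM, the highest of the three numbers measured so far. Compound 2 (`COc1ccc(/C=C/C(=O)c2ccccc2-c2ccc(OC)c(OC)c2)cc1`) gives 600 nM, and compound 3 (`COc1ccc(OC)c(/C=C/C(=O)c2ccccc2-c2ccc(OC)c(OC)c2)c1`) gives 2100 nM.

Compound 4 (`COc1ccc(-c2ccccc2C(=O)/C=C/c2ccc(Br)cc2)cc1OC`) has not yet been measured. It carries bromo in place of fluoro on an aromatic carbon, para to a large group: bromo in place of fluoro on an aromatic carbon.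

Two measured changes start from the same 4-fluorophenyl group of compound 1. Methoxy in place of fluoro gives a 7.2-fold lower number from compound 1 to compound 2 (0.86 log units; beyond the scatter), and 2,5-dimethoxyphenyl in place of 4-fluorophenyl gives a 2.0-fold lower number from compound 1 to compound 3 (0.31 log units; beyond the scatter). The step of a 3.5-fold higher number from compound 2 to compound 3 (0.54 log units; beyond the scatter) shows that the size of the change depends on what enters. For the measured compounds named here, both departures from fluoro lower the number, but neither brings in bromo, and no measured compound carries it, so this evidence is only indirect.

A small step toward a lower number is therefore expected in this assay, smaller than the one seen with methoxy and possibly hidden by the scatter. The expected step is a 1.7-fold lower number from compound 1 to compound 4 (0.24 log units; within the scatter). For compound 4 the estimated value is 2500 nM, with an expected range of 800 nM to 6000 nM.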

Compound 4, half-maximal inhibitory concentration: 3300 nM
For compound 4 the middle estimate is 1.3-fold (0.12 log units) below the measured one; measured number inside the range.
By their numbers in this assay, from the lowest: compound 2; then compounds 3, 4 and 1 (each within the scatter of the next, the first and the last beyond it).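

In this assay, among the compounds shown here, the first change at this position to stay within the scatter is the exchange of fluoro for bromo, a 1.3-fold lower number from compound 1 to compound 4 (0.11 log units; within the scatter), so no effect of this exchange can be read at this place, para to a large group. For the compounds shown here, the 4-bromophenyl group also cannot be separated from the 2,5-dimethoxyphenyl group, a 1.6-fold higher number from compound 3 to compound 4 (0.20 log units; within the scatter), whereas replacing methoxy with bromo gives a step beyond the scatter, a 5.5-fold higher number from compound 2 to compound 4 (0.74 log units; beyond the scatter), leaving the 4-methoxyphenyl group of compound 2 as the only one of the four groups whose number stands apart from all the others. The data shown offer no explanation for this separation.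

From the compounds shown here alone, it remains open whether a dimethylamino group, a carboxylic acid or a longer chain such as butoxy at this same place would stand apart as methoxy does or would fall with fluoro and bromo. Going by these compounds, it is also open whether fluoro and bromo would stay this close on a core without the two methoxy groups that compound 1 and compound 4 share.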